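A few compounds are considered here, and "the series" means these few. Any claim that something is new, unique, unknown or untested is made for them only; others in the source may bear on it.

Measured so far:
compound 1 `c1ccc2c(c1)CN[C@H](CN(CCCN1CCNCC1)[C@H]1CCCc3cccnc31)C2` – 1150 nM
compound 2 `CN1CCN(CCCN(C[C@H]2Cc3ccccc3CN2C)[C@H]2CCCc3cccnc32)CC1` – 536 nM

Of the compounds shown here, two sharing the same core have been tested in a functional assay on CCRF-CEM cells for antagonist activity at C-X-C chemokine receptor type 4 (Homo sapiens), read by calcium flux, with stated times of 25 min and 90 s; a higher number here means a weaker inhibitor, a lower number a stronger inhibitor. Compound 1 gives 1150 nM, while compound 2 gives 536 nM. Of these two numbers, compound 1 has the higher one, and the gap to compound 2 is wide enough to count as a real difference rather than scatter, so compound 1 is the weaker inhibitor of the pair.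

The next compound, compound 3 `c1cnc(CN(CCCN2CCNCC2)[C@H]2CCCc3cccnc32)nc1`, has not yet been measured in this assay. It differs from compound 1 in one place: pyrimidin-2-yl in place of 1,2,3,4-tetrahydroisoquinolin-3-yl on a saturated chain carbon bound to an amine nitrogen. For the measured compounds named here, no measured pair in this set shows what this kind of exchange does, so the direction of the step has to be guessed rather than read from the data. Going by the values given here, since compound 1 already sits at the weaker end of the two known numbers, and the exchange removes a larger group in favour of a smaller one, the expectation is a modest move to a higher number, as a 1.9-fold higher number from compound 1 to compound 3 (0.28 log units; within the scatter), though a change within the scatter cannot be ruled out. For compound 3 the estimated result in this assay is 2200 nM, with a range of 600 nM to 8000 nM.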

Compound 3, half-maximal inhibitory concentration: 4320 nM
Compound 3: middle estimate off by 2.0-fold (0.29 log units), on the low side, and the stated range covers the measured number.
By their numbers in this assay, from the lowest: compound 2; then compound 1; then compound 3.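

In this assay, for the compounds shown here, this is the first measured exchange on a saturated chain carbon bound to an amine nitrogen, and pyrimidin-2-yl in place of 1,2,3,4-tetrahydroisoquinolin-3-yl gives a 3.8-fold higher number from compound 1 to compound 3 (0.57 log units; beyond the scatter) and so a weaker inhibitor, which shows that the group at this place matters for inhibition in this set. The exchange alters several features at once: 1,2,3,4-tetrahydroisoquinolin-3-yl has 10 heavy atoms, 1 hydrogen-bond donor and 1 defined stereocentre, while pyrimidin-2-yl has 6 heavy atoms, 0 hydrogen-bond donors and 2 hydrogen-bond acceptors, so this single step cannot say which feature counts. Nothing measured on these compounds accounts for the rise in the number.

On these data alone, it remains open whether the loss of inhibition follows the size of the group, its ring nitrogen atoms or the hydrogen-bond donor that leaves with the 1,2,3,4-tetrahydroisoquinolin-3-yl group. A simple phenyl ring or a piperidin-3-yl ring at the same place would be the kind of group that could begin to separate these possibilities.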